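Ring for chain on the pyrazole nitrogen: back to a ring

The source may hold more compounds than are shown below. What is called first, only, known or untested is meant among the compounds shown, and "the series" means these compounds.

Measured compounds:
Compound 1, `Nc1ncnc2c1c(-c1cc(C3CC3)on1)nn2C1CCCCC1`: 290 nM
Compound 2, `CCCCCCCn1nc(-c2cc(C3CC3)on2)c2c(N)ncnc21`: > 10000 nM

In an assay on TT cells for inhibition of proto-oncogene tyrosine-protein kinase receptor Ret variant C634W (Homo sapiens), read by MTT assay, with a stated time of 10 days (a higher number here means a weaker inhibitor of growth, a lower number a stronger inhibitor of growth), compound 1 gives 290 nM. Compound 2 gives only a limit in this assay, > 10000 nM, so its true number is not known (the limit of > 10000 nM in this assay, at which 1 of the 2 values shown sits). Going by the values given here, the one measured step, an at least 34-fold higher number from compound 1 to compound 2 (1.53 log units; beyond the scatter), shows that swapping the cyclohexyl ring for a straight heptyl chain costs a great deal of growth inhibition.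

Compound 3, `Nc1ncnc2c1c(-c1cc(C3CC3)on1)nn2C1CCOCC1`, has not been measured. It differs from compound 2 by oxan-4-yl in place of heptyl on an aromatic nitrogen. This reverses the direction of the measured step: a chain leaves and a six-membered ring enters again, much as in compound 1, now with one oxygen in the ring. Among the compounds with values here, only the step from compound 1 to compound 2 bears on this change, and it was large. The expectation is therefore a large drop in the number for this assay, roughly undoing that loss. Compound 3 is estimated at 500 nM, within 100 nM to 3000 nM. This amounts to an expected step of an at least 20-fold lower number from compound 2 to compound 3 (1.30 log units; beyond the scatter).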

Compound 3, concentration for 50% growth inhibition: 940 nM
Estimate against measurement, compound 3: 1.9-fold (0.27 log units) below, within the range that was stated.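

Putting a six-membered ring back on this aromatic nitrogen restores much of the growth inhibition in this assay, with an at least 10-fold lower number from compound 2 to compound 3 (1.02 log units; beyond the scatter) as the step from chain to ring. From the compounds shown here alone, compound 2 gives only a limit, so the true size of that step is unknown: the limit of > 10000 nM in this assay, at which 1 of the 3 values shown sits. The two rings are still not interchangeable, since a 3.2-fold higher number from compound 1 to compound 3 (0.51 log units; beyond the scatter) is a modest step that shows that this position responds to oxan-4-yl in place of cyclohexyl, even though both are six-membered rings.

What the compounds shown leave open is whether heptyl falls short through its length or through having no ring, and a shorter chain such as propyl, or a smaller ring such as cyclopentyl, would help to separate those two readings. They also leave open how the position would respond to a piperidine ring, with a nitrogen where oxan-4-yl has its oxygen, or to a hydroxyl group on the cyclohexyl ring.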